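This account rests on a few compounds, and the source may have more. Where it says the series, first, only, none or still open, it means among the compounds named here.

Compound 1 `O=S(=O)(Nc1ccc(-c2nc3ccccc3o2)cc1)c1ccc(Cl)s1`: > 63000 nM
Compound 2 `O=S(=O)(Nc1ccc(-c2nc3ccccc3o2)cc1)c1cccc(O)c1`: > 63000 nM
Compound 3 `O=S(=O)(Nc1ccc2oc(-c3ccccc3)nc2c1)c1ccccc1Cl`: > 63000 nM

In an assay on isolated protein for inhibition of malate dehydrogenase, mitochondrial (Sus scrofa), with stated times of 45 min and 30 min (on this read-out higher numbers stand for weaker inhibition and lower numbers for stronger inhibition), compound 3 gives > 63000 nM, which is a limit of the assay and not a number. Compound 1 likewise gives only a limit, > 63000 nM. Compound 2 also gives only a limit, > 63000 nM. Within the data shown here, every value shown therefore rests at the limit of > 63000 nM in this assay, at which 3 of the 3 values shown sit, and the single step between measured compounds, a step that the two limits leave unreadable from compound 1 to compound 2, cannot be read. Compound 4 `O=S(=O)(Nc1ccc2oc(-c3ccccc3)nc2c1)c1ccc(Cl)c(Cl)c1` differs from compound 3 by 3,4-dichlorophenyl in place of 2-chlorophenyl on a sulfonyl sulfur. Among the measured compounds shown here, no measured step touches this change, and no step of readable size exists at all, so nothing points to a gain or loss beyond the scatter. Compound 4 is therefore expected to sit where compound 3 sits, at an estimated 100000 nM within 30000 nM to 400000 nM, an expected step that the limit leaves unreadable from compound 3 to compound 4, most likely reported again only as a limit.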

Compound 4, half-maximal inhibitory concentration: > 63000 nM
Compound 4 gave a limit, no number; the forecaster's own chance of this, stated with the estimate: 80%; the middle value does not contradict the limit.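

Compound 3 and compound 4 each give only a limit of the assay, so no step between them can be read: the limit of > 63000 nM in this assay, at which 4 of the 4 values shown sit.

The compounds shown leave open which structural change, if any, would give a measured number instead of a limit.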